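A few compounds are considered here, and "the series" means these few. Any claim that something is new, unique, unknown or untested is made for them only; others in the source may bear on it.

Compound 1 `O=C1C(Nc2ccccc2)=CC(=O)c2c1nc1n2[C@H]2OC[C@@H](O)[C@H]2OC1` is the reference point of the series. In a functional assay on ECa-109 cells for inhibition, with ECa-109 cell line (Homo sapiens) as the target, read by sulforhodamine B assay (a higher number here means a weaker inhibitor, a lower number a stronger inhibitor), compound 1 gives 3560 nM, the only actual number among the three results shown. Compound 2 `O=C1C=C(N2CCC2)C(=O)c2c1nc1n2[C@H]2OC[C@@H](O)[C@H]2OC1` reaches only the assay limit of > 16000 nM. Compound 3 `O=C1C=C(NC2CCCCC2)C(=O)c2c1nc1n2[C@H]2OC[C@@H](O)[C@H]2OC1` likewise returns a limit, > 16000 nM. Going by the values given here, the one comparable pair therefore yields a step that the two limits leave unreadable from compound 2 to compound 3, and the common boundary is simply (the limit of > 16000 nM in this assay, at which 2 of the 3 values shown sit), which carries no information about how far either compound lies beyond it.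

Compound 4 `COc1ccc(NC2=CC(=O)c3c(nc4n3[C@H]3OC[C@@H](O)[C@H]3OC4)C2=O)cc1` takes compound 1 and alters the anilino group: methoxy in place of hydrogen on an aromatic carbon. Among the compounds with values here, no measured step touches this part of the molecule; the two limits concern replacements of the whole anilino group by other amines, not a substituent on its ring. Within the data shown here, the only anchor is thus compound 1 itself. A change of this kind is expected to stay within the usual scatter, so for compound 4 a step of a 1.2-fold lower number from compound 1 to compound 4 (0.07 log units; within the scatter) is anticipated. Compound 4 is therefore estimated at 3000 nM, with a range from 1200 nM to 9000 nM.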

Compound 4, half-maximal inhibitory concentration: 3410 nM
Compound 4: the middle estimate sits 1.1-fold (0.06 log units) below what was measured; low and high end bracket the measured number.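

In this assay, going by these compounds alone, the result adds the first readable step, a 1.0-fold lower number from compound 1 to compound 4 (0.02 log units; within the scatter), and it concerns a substituent on the anilino ring rather than a replacement of the whole anilino group. Methoxy in place of hydrogen, on an aromatic carbon para to a large group, leaves the reading where it stood, so this position accepts this one group without a change that can be told from scatter. Nothing shown accounts for this absence of a change.

As far as these compounds go, whether the same position stays as unresponsive to other groups remains open, for instance to a carboxylic acid, an amine or a longer chain such as butoxy. Also open, from the compounds shown here alone, is whether methoxy would behave the same way at another carbon of that ring.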